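Adding Chloro to Compound 2: An Expected Small Step

A few compounds are considered here, and "the series" means these few. Any claim that something is new, unique, unknown or untested is made for them only; others in the source may bear on it.

In an ADME assay for pharmacokinetics (on this read-out higher numbers stand for a longer-lived compound and lower numbers for a shorter-lived compound), three compounds sharing one core have been measured. Compound 1 `N#Cc1cccc(-n2nnc3c(C(N)=O)ncn3c2=O)c1` gives 0.0433 h, compound 2 `NC(=O)c1ncn2c(=O)n(-c3ccccc3)nnc12` gives 0.383 h, and compound 3 `CCCn1nnc2c(C(N)=O)ncn2c1=O` gives 2.58 h. Compound 2 thus stands second highest of the three, with compound 3 above it and compound 1 below it, both gaps beyond the scatter.

Compound 4 `NC(=O)c1ncn2c(=O)n(-c3ccc(Cl)cc3)nnc12` has not yet been measured. It differs from compound 2 by chloro in place of hydrogen on an aromatic carbon, with chloro in place of hydrogen on an aromatic carbon, para to a large group.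

Of the measured steps, the closer one is an 8.8-fold higher number from compound 1 to compound 2 (0.95 log units; beyond the scatter), with hydrogen in place of cyano on an aromatic carbon. Read backwards, it shows the compound carrying the added group on the aromatic ring with the lower number. The other step, a 6.7-fold higher number from compound 2 to compound 3 (0.83 log units; beyond the scatter), has propyl in place of phenyl on an aromatic nitrogen and changes a different place, so it offers little guidance. Cyano and chloro are different groups, and no chloro compound has yet been measured, so only a cautious reading is possible. The expected change is a 1.5-fold lower number from compound 2 to compound 4 (0.19 log units; within the scatter), a smaller move in the same downward direction that may stay within the scatter. For compound 4 the estimated value is 0.25 h, with an expected range from 0.1 h to 0.6 h.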

Compound 4, half-life: 0.105 h
The estimate for compound 4 lay 2.4-fold (0.38 log units) above the measured number, and the stated range covers the measured number.
By their numbers in this assay, from the lowest: compound 1; then compound 4; then compound 2; then compound 3.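

In this assay, chloro in place of hydrogen on an aromatic carbon, para to a large group, brings a 3.6-fold lower number from compound 2 to compound 4 (0.56 log units; beyond the scatter), so this one change on the phenyl ring is enough to move the number beyond the scatter. Among these compounds, until now, cyano was the only group seen on that ring, and a lower number could have belonged to cyano alone; now compound 1 at 0.0433 h and compound 4 at 0.105 h both stand under compound 2 at 0.383 h, so two different groups on the ring go with a shorter half-life than the bare phenyl. Nothing available here offers an explanation for this drop.

The compounds shown leave open whether the same downward move would follow from fluoro, methoxy or an amine in the same place, or whether some group there would raise the number instead. They also leave open whether chloro on another carbon of the ring would give a step of similar size, and whether any substituted phenyl compound could approach compound 3 at 2.58 h.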